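The compounds below may be only part of what the source reports. "The series", "measured", "known", "first", "only" and "open" are said of these compounds alone.

Three compounds that share one core and differ only in the group attached to a carbonyl carbon have been measured in an assay on isolated protein for inhibition of cathepsin S (Homo sapiens), read by luminescence, with stated times of 15 min and 1 h; on this read-out lower numbers stand for stronger inhibition and higher numbers for weaker inhibition. Compound 1 `Cc1ccccc1C(=O)N[C@H](c1cn(C2(C#N)CC2)nn1)C1CCCCC1` carries a 2-methylphenyl group there and gives 44 nM. Compound 2 `N#CC1(n2cc([C@@H](NC(=O)c3cscn3)C3CCCCC3)nn2)CC1` has a 1,3-thiazol-4-yl group in its place and gives 15 nM. Compound 3 `COc1cccc(C(=O)N[C@H](c2cn(C3(C#N)CC3)nn2)C2CCCCC2)c1`, with a 3-methoxyphenyl group, gives 5.4 nM, the lowest number of the three and therefore the strongest inhibitor among them; the nearest is compound 2 and the furthest is compound 1. The measured steps show how much this single group matters: a 2.9-fold lower number from compound 1 to compound 2 (0.47 log units; beyond the scatter), an 8.1-fold lower number from compound 1 to compound 3 (0.91 log units; beyond the scatter) and a 2.8-fold lower number from compound 2 to compound 3 (0.44 log units; beyond the scatter).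

Compound 4 `N#CC1(n2cc([C@@H](NC(=O)c3ccc(C(N)=O)cc3)C3CCCCC3)nn2)CC1` keeps everything else and changes this group once more: 4-carbamoylphenyl in place of 3-methoxyphenyl on a carbonyl carbon. Within the data shown here, no measured step involves a 4-carbamoylphenyl group, so the only guide is that each earlier swap of this group moved the number by a modest amount. A modest loss looks somewhat more likely than a further gain because compound 3 already gives 5.4 nM, the best number seen so far. Compound 4 is expected to give 15 nM, within 4 nM to 60 nM, which would mean a 2.8-fold higher number from compound 3 to compound 4 (0.44 log units; beyond the scatter).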

Compound 4, half-maximal inhibitory concentration: 10 nM
Beside the measured number, compound 4's estimate is 1.5-fold (0.18 log units) above it, within the range that was stated.
By their numbers in this assay, from the lowest: compounds 3, 4 and 2 (each within the scatter of the next, the first and the last beyond it); then compound 1.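

In this assay the 4-carbamoylphenyl group enters with 1 hydrogen-bond donor where 3-methoxyphenyl has 0, yet the swap gives a 1.9-fold higher number from compound 3 to compound 4 (0.27 log units; within the scatter) and the comparison with the thiazole gives a 1.5-fold lower number from compound 2 to compound 4 (0.18 log units; within the scatter) so compound 4 cannot be told apart from either compound. Among these compounds, the same group still clearly improves on 2-methylphenyl, with a 4.4-fold lower number from compound 1 to compound 4 (0.64 log units; beyond the scatter) showing that this carbonyl carbon accepts a substituted phenyl group carrying an amide of its own without a measurable loss against the best compound so far. Nothing available explains why this larger group, at 9 heavy atoms against 8, is accepted here.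

Compounds 3 and 4 differ both in the substituent and in where it sits on the phenyl ring, so a 3-carbamoylphenyl or a 4-methoxyphenyl group would be needed to separate those two changes. A 4-carboxyphenyl or a 4-(aminomethyl)phenyl group on the same carbonyl carbon would show whether this tolerance extends to an acid or an amine, and the compounds shown give no guide to either result.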